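The source may report more compounds than this note shows. Statements on the series, on what has been measured and on what is new or still open speak of the compounds shown alone.

In a functional assay on A549 cells (Homo sapiens) for cytotoxicity, read by MTT assay, with a stated time of 72 h (on this read-out higher numbers stand for weaker inhibition and lower numbers for stronger inhibition), compound 1 `CC(C)[S+]([O-])CCCCN=C=S` gives 10400 nM, and compound 3 `CC(C)[S+]([O-])CCCCCN=C=S` gives 7750 nM. These two differ in one change, (a group of 4 heavy atoms (2 carbon, 1 nitrogen, 1 sulfur; no ring) in place of a group of 3 heavy atoms (1 carbon, 1 nitrogen, 1 sulfur; no ring), on a saturated chain carbon, four bonds along the chain from a sulfur), and that change made a step of a 1.3-fold lower number from compound 1 to compound 3 (0.13 log units; within the scatter). Compound 2 `[O-][S+](CCCCCN=C=S)Cc1ccccc1` gives 6210 nM in this assay; the difference between its core and the core of compound 1 is not broken down here. Compound 4 `[O-][S+](CCCCCCN=C=S)Cc1ccccc1` has not yet been measured in this assay. It differs from compound 2 by a group of 4 heavy atoms (2 carbon, 1 nitrogen, 1 sulfur; no ring) in place of a group of 3 heavy atoms (1 carbon, 1 nitrogen, 1 sulfur; no ring), on a saturated chain carbon, five bonds along the chain from a sulfur, the same kind of change as before, though here the place is five bonds along the chain from a sulfur rather than four bonds along the chain from a sulfur. Because a 1.3-fold lower number from compound 1 to compound 3 (0.13 log units; within the scatter) stayed within the scatter, the step expected from compound 2 to compound 4 is of similar size, namely a 1.1-fold lower number from compound 2 to compound 4 (0.05 log units; within the scatter). For compound 4 the expected value in this assay is 5500 nM, estimated to fall between 2500 nM and 12000 nM.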

Compound 4, half-maximal inhibitory concentration: 14700 nM
Estimate against measurement, compound 4: 2.7-fold (0.43 log units) below, outside the stated range (above it).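

In this assay, the change gave a 2.4-fold higher number from compound 2 to compound 4 (0.37 log units; beyond the scatter) on this core, so it did not carry over from one core to the other with the same result: the same change on two cores in this assay, a 1.3-fold lower number (0.13 log units; within the scatter) from compound 1 to compound 3 and a 2.4-fold higher number (0.37 log units; beyond the scatter) from compound 2 to compound 4, 3.2-fold (0.50 log units) apart, beyond the scatter of two such steps. The place of the change also differs between the two steps, four bonds along the chain from a sulfur in one and five bonds in the other, so the core and the place cannot be told apart as the source of this gap. With one step on each core, nothing here shows why the steps differ or how a third core would respond.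

As far as these compounds go, a longer chain on the core of compound 1 remains open, as it would put the change at the same place as in compound 4. From the compounds shown here alone, how an amine in place of the group that enters would behave on either core is also open.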